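Changing the ring on the double-bonded carbon once more

The compounds below may be only part of what the source reports. "The series", "measured", "known", "first", "only" and "open" are said of these compounds alone.

Two compounds share one core and differ only in the ring attached to a carbon with a double bond to nitrogen. In a functional assay on A549 cells (Homo sapiens) for cytotoxicity, read by MTT assay, with a stated time of 72 h (on this read-out lower numbers stand for stronger inhibition and higher numbers for weaker inhibition), compound 2 `CN(C)CCn1cnnc1-c1cc(Oc2ccc(NC(=O)N/N=C/c3ccccc3O[N+](=O)[O-])cc2F)ccn1` gives 1200 nM, and compound 1 `CN(C)CCn1cnnc1-c1cc(Oc2ccc(NC(=O)N/N=C/c3ccc(O)c(Br)c3)cc2F)ccn1` gives 1370 nM; these two values lie within the scatter of each other, as the step of a 1.1-fold lower number from compound 1 to compound 2 (0.06 log units; within the scatter) shows. Compound 3 `CN(C)CCn1cnnc1-c1cc(Oc2ccc(NC(=O)N/N=C/c3ccc(F)cc3)cc2F)ccn1` alters the same place again: 4-fluorophenyl in place of 2-(nitrooxy)phenyl on a carbon with a double bond to nitrogen. Within the data shown here, the only measured step that bears on this, a 1.1-fold lower number from compound 1 to compound 2 (0.06 log units; within the scatter), left this assay essentially unmoved, so no step beyond the scatter is expected, a 1.2-fold higher number from compound 2 to compound 3 (0.07 log units; within the scatter). Compound 3 is therefore estimated at 1400 nM, with a range from 600 nM to 3500 nM.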

Compound 3, half-maximal inhibitory concentration: 1790 nM
Estimate against measurement, compound 3: 1.3-fold (0.11 log units) below; the range from low to high includes it.
By their numbers in this assay, from the lowest: compounds 2, 1 and 3 (each within the scatter of the next).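

In this assay, the new ring again leaves the number close to the others: the steps, a 1.5-fold higher number from compound 2 to compound 3 (0.17 log units; within the scatter) and a 1.3-fold higher number from compound 1 to compound 3 (0.12 log units; within the scatter), both stay inside the usual scatter. Thus 4-fluorophenyl, 2-(nitrooxy)phenyl and 3-bromo-4-hydroxyphenyl cannot be told apart on this carbon, although 4-fluorophenyl has fewer heavy atoms than 2-(nitrooxy)phenyl and no hydrogen-bond acceptors. Nothing at hand accounts for this result. Still open, from the compounds shown here alone, is whether a ring carrying an amine or a carboxylic acid, or a saturated cyclohexyl ring, would move the number beyond the scatter.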